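The source may hold more compounds than are shown below. What is called first, only, known or untested is meant among the compounds shown, and "the series" means these compounds.

The measured compounds:
- compound 1 `COc1cc(Oc2cccc(Nc3ccccc3)c2)cc(OC)c1CNCc1ccc(Cl)cc1` gives 3310 nM
- compound 2 `COc1cc(Oc2cccc(Nc3ccccc3)c2)cc(OC)c1CNC(C)C` gives the limit > 20000 nM
- compound 3 `COc1ccc(CNCc2c(OC)cc(Oc3cccc(Nc4ccccc4)c3)cc2OC)cc1` gives 2620 nM

In a functional assay on HCT-116 cells (Homo sapiens) for inhibition, read by MTT assay, with a stated time of 72 h (on this read-out higher numbers stand for weaker inhibition and lower numbers for stronger inhibition), compound 1 stands highest of the two numbers, and its nearest neighbour is compound 3, reached by a 1.3-fold lower number from compound 1 to compound 3 (0.10 log units; within the scatter) when methoxy takes the place of chloro on an aromatic carbon. Compound 2 gives only a limit of this assay, not a number, as the limit of > 20000 nM in this assay, at which 1 of the 3 values shown sits, records. Swapping the whole amine substituent moves far more: an at least 6.0-fold higher number from compound 1 to compound 2 (0.78 log units; beyond the scatter) and an at least 7.6-fold lower number from compound 2 to compound 3 (0.88 log units; beyond the scatter).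

Compound 4 `COc1cc(Oc2cccc(Nc3ccccc3)c2)cc(OC)c1CNCc1ccccc1` differs from compound 1 only by hydrogen in place of chloro on an aromatic carbon. The step that bears on it most directly is the exchange at the same aromatic carbon, which stayed within the scatter; the two large steps concern a different change, the isopropyl for a benzyl group, and say little here. A step of no more than the usual scatter is therefore expected, with no clear direction: compound 4 is estimated at 3300 nM (range 1500 nM to 7500 nM), that is, an expected 1.0-fold lower number from compound 1 to compound 4 (0.00 log units; within the scatter).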

Compound 4, half-maximal inhibitory concentration: 4070 nM
Beside the measured number, compound 4's estimate is 1.2-fold (0.09 log units) below it; the range from low to high includes it.
By their numbers in this assay, from the lowest: compounds 3, 1 and 4 (each within the scatter of the next). At a limit, above all of these: compound 2.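

Hydrogen in place of chloro gives a 1.2-fold higher number from compound 1 to compound 4 (0.09 log units; within the scatter), and hydrogen in place of methoxy gives a 1.6-fold higher number from compound 3 to compound 4 (0.19 log units; within the scatter), so in this assay the plain benzyl group reads the same, within the scatter, as its two substituted forms, and neither substituent is needed at this aromatic carbon. The plain benzyl group still separates from isopropyl on the amine nitrogen, with an at least 4.9-fold lower number from compound 2 to compound 4 (0.69 log units; beyond the scatter), so the difference from compound 2 does not depend on a substituent on the benzyl ring. That step starts from a limit, not a number: the limit of > 20000 nM in this assay, at which 1 of the 4 values shown sits.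

On these data alone, only chloro, methoxy and hydrogen appear at this aromatic carbon, so it stays open whether a carboxylic acid or an amine there would leave the number unchanged. Also open, as far as these compounds go, is how a cyclohexylmethyl group on the amine nitrogen would compare with benzyl and isopropyl.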